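The source may hold more compounds than are shown below. What is called first, only, known or untested is meant among the compounds shown, and "the series" means these compounds.

Measured compounds:
Compound 1 `O=C(NC1(c2ccccc2)CC1)c1ccc([N+](=O)[O-])o1`: in an ADME assay on Vero cells (Chlorocebus sabaeus) for cytotoxicity, read by MTT assay, with a stated time of 48 h (on this read-out lower numbers stand for higher toxicity in this test and higher numbers for lower toxicity in this test), compound 1 gives 46000 nM.
Compound 2 `O=C(Nc1ccc2ccccc2c1)c1ccc([N+](=O)[O-])o1`: in this assay compound 2 reaches only the assay limit > 150000 nM.
Compound 3 `COc1ccc(C(C)(C)NC(=O)c2ccc([N+](=O)[O-])o2)cc1`: in this assay compound 3 gives 82000 nM.

Compound 2 accounts for (the limit of > 150000 nM in this assay, at which 1 of the 3 values shown sits), so it supplies no number, only a limit. Among the two numbers that remain, compound 3 and compound 1 are separated by a gap that lies within the usual scatter of this kind of measurement, and the two are therefore read as alike.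

Compound 4 `CC(C)(NC(=O)c1ccc([N+](=O)[O-])o1)c1ccc(C#N)cc1` has not yet been measured in this assay. It departs from compound 3 by cyano in place of methoxy on an aromatic carbon. Among the measured compounds shown here, no measured pair in this set differs in only one place, so there is no directly comparable step to draw on; the three measured values sit close together or at the limit, and nothing among them points to a large shift in either direction for a change of this kind.

Compound 4 is therefore estimated to give 80000 nM in this assay, with a range from 30000 nM to 150000 nM. The step of a 1.0-fold lower number from compound 3 to compound 4 (0.01 log units; within the scatter) is expected to stay within the scatter, with a fair chance that the assay again reports only a limit.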

Compound 4, half-maximal cytotoxic concentration: 83000 nM
Compound 4: middle estimate off by 1.0-fold (0.02 log units), on the low side; the range from low to high includes it.
By their numbers in this assay, from the lowest: compounds 1, 3 and 4 (each within the scatter of the next). At a limit, above all of these: compound 2.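

In this assay, among the compounds shown here, cyano in place of methoxy on an aromatic carbon, para to a large group, is the first change in a single place that can be read in this set, and it gives a 1.0-fold higher number from compound 3 to compound 4 (0.01 log units; within the scatter). At this position, compound 3 and compound 4 therefore read as alike on this read-out, even though the entering group carries a triple bond outside aromatic rings and the leaving group does not. The data shown offer no measured property that would account for this likeness.

This single step leaves open whether an amine, a carboxylic acid or a longer chain on the same aromatic carbon would also stay within the scatter of compound 3, or whether only some groups can be exchanged there without a visible step. Compound 1 and compound 2 each differ from compound 3 in more than one place, so the effect of changing any other part of the structure on this read-out also remains unresolved.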